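The source may hold more compounds than are shown below. What is called first, only, known or untested is meant among the compounds shown, and "the series" means these compounds.

Working notes on the series. In a functional assay on MCF7 cells (Homo sapiens) for cytotoxicity, read by MTT assay, with a stated time of 72 h, tested at 1 uM (a lower number here means less inhibition of growth, a higher number more inhibition of growth at the concentration tested), compound 1 `N/C(=N\NC(=S)N1CCOCC1)c1ccccn1` gives 14.7%, compound 2 `Cc1ccnc(/C(N)=N/NC(=S)N2CCOCC2)c1` gives 1.22% and compound 3 `N/C(=N\NC(=S)N1CCCC1)c1ccc(F)cn1` gives 51%. Among the measured compounds shown here, the one single-point step measured so far is a number 13.5 percentage points lower from compound 1 to compound 2 (beyond the scatter). Compound 2 thus stands lowest of the three numbers in this assay; nearest is compound 1, furthest compound 3, whose structure differs from compound 1 in two places, so the two values are only set side by side here.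

The next compound, compound 4 `Cc1ccnc(/C(N)=N/NC(=S)N2CCCCC2)c1`, is reached from compound 2 by piperidin-1-yl in place of morpholin-4-yl on a thiocarbonyl carbon. For the measured compounds named here, no measured step in this assay changes the ring on the thiocarbonyl carbon alone, so nothing directly bears on this change; the only exchange at that carbon sits in compound 3 together with a second difference. On that basis a step in this assay of at most modest size is expected, and the estimate for compound 4 is 8%, within -5% to 30%, meaning an expected step of a number 6.8 percentage points higher from compound 2 to compound 4 (within the scatter).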

Compound 4, percent growth inhibition at one concentration: 21.2%
Beside the measured number, compound 4's estimate is 13.2 percentage points below it, and the stated range covers the measured number.
By their numbers in this assay, from the lowest: compound 2; then compounds 1 and 4 (each within the scatter of the next); then compound 3.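

In this assay, among the compounds shown here, the exchange on the thiocarbonyl carbon gives the first single-place reading at this position: piperidin-1-yl in place of morpholin-4-yl yields a number 20 percentage points higher from compound 2 to compound 4 (beyond the scatter). The exchange removes the ring oxygen and its hydrogen-bond acceptor, while the ring size and the heavy-atom count stay the same. The read-out on the core of compound 2 therefore responds to this one atom exchange, but no measured information accounts for the step.

From the compounds shown here alone, whether the same exchange gives a step of similar size on the core of compound 1, which lacks the methyl, stays open. Also open, going by these compounds, is where a dimethylamino group or a piperazin-1-yl ring on the thiocarbonyl carbon would fall relative to these two rings.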